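The source may hold more compounds than are shown below. What is called first, only, known or untested is meant among the compounds shown, and "the series" means these compounds.

Measured in an ADME assay on MT4 cells (Homo sapiens) for cytotoxicity, read by MTT assay, with a stated time of 4 days; on this read-out higher numbers stand for lower toxicity in this test and lower numbers for higher toxicity in this test:
- compound 1 `Nc1ccc2oc(-c3ccccc3F)cc(=O)c2c1`: 283000 nM
- compound 2 `Nc1ccc2oc(-c3ccccc3)c(O)c(=O)c2c1`: 217000 nM
- compound 3 `COc1ccccc1-c1oc2ccc(N)cc2c(=O)c1O`: 222000 nM

Compound 3 stands within the scatter of both other compounds, so these three values give no order. The next compound to read is compound 4 `Nc1ccc2oc(-c3ccccc3F)c(O)c(=O)c2c1`. Its difference from compound 3 is fluoro in place of methoxy on an aromatic carbon, ortho to a large group.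

For the measured compounds named here, no measured step makes this exchange directly. Going by the values given here, the one measured step that bears on it is a 1.0-fold higher number from compound 2 to compound 3 (0.01 log units; within the scatter), where methoxy takes the place of hydrogen on an aromatic carbon. That step is within the scatter, so the methoxy group has shown no measurable effect on the number so far. Compound 1 also carries fluoro and gives 283000 nM, a value that likewise lies within the scatter of compound 3.

With only this to go on, no step beyond the scatter is expected in this assay, and no direction can be assigned. The estimated step is a 1.1-fold higher number from compound 3 to compound 4 (0.02 log units; within the scatter). For compound 4 the estimated value is 235000 nM, with an expected range from 130000 nM to 380000 nM.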

Compound 4, half-maximal cytotoxic concentration: 44500 nM
The estimate for compound 4 lay 5.3-fold (0.72 log units) above the measured number, outside the stated range (below it).
By their numbers in this assay, from the lowest: compound 4; then compounds 2, 3 and 1 (each within the scatter of the next).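

In this assay this place, an aromatic carbon ortho to a large group, now responds to the group it carries: fluoro in place of hydrogen gives a 4.9-fold lower number from compound 2 to compound 4 (0.69 log units; beyond the scatter) and fluoro in place of methoxy gives a 5.0-fold lower number from compound 3 to compound 4 (0.70 log units; beyond the scatter), whereas methoxy in place of hydrogen gave only a 1.0-fold higher number from compound 2 to compound 3 (0.01 log units; within the scatter) and stayed within the scatter. The change is also sensitive to the hydroxy group on the shared core, since with fluoro present the added hydroxy gives a 6.4-fold lower number from compound 1 to compound 4 (0.80 log units; beyond the scatter) and leaves compound 4 as the lowest number of the four, the most toxic in this test. (Nothing measured alongside these numbers accounts for the drop)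

Open, on these data alone, is whether the drop is particular to fluoro or would also appear with chloro, bromo, a methyl group or an amine at this place, and whether fluoro at another place on the same ring would do the same. Also open, as far as these compounds go, is what hydroxy in place of hydrogen does when the ring carries no fluoro, a pair absent from these four compounds.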